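Working notes on the step from compound 2 to compound 4

This account rests on a few compounds, and the source may have more. Where it says the series, first, only, none or still open, it means among the compounds named here.

In a functional assay on XF498 cells (Homo sapiens) for inhibition, with a stated time of 72 h (a higher number here means a weaker inhibitor, a lower number a stronger inhibitor), compound 1 `CC1(c2ccccc2)CC(=O)C(C(CC(=O)c2ccc(-c3ccc(Br)cc3)cc2)c2ccccc2)=C(O)O1` gives 6730 nM. Compound 2 `CC1(c2ccccc2)CC(=O)C(C2CC(c3ccc(OCc4ccc(C(F)(F)F)cc4)cc3)Cc3ccccc32)=C(O)O1` gives only a limit of the assay, > 10000 nM. Compound 3 `COc1ccc(C2Cc3ccccc3C(C3=C(O)OC(C)(c4ccccc4)CC3=O)C2)cc1` likewise gives only a limit, > 10000 nM. Compound 2 thus stands at the edge of what this assay reports, together with one other value. The step that the two limits leave unreadable from compound 2 to compound 3, which puts hydrogen in place of 4-(trifluoromethyl)phenyl on a saturated chain carbon bound to an oxygen on an aromatic ring, cannot be sized, since both ends sit at the limit of > 10000 nM in this assay, at which 2 of the 3 values shown sit.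

Compound 4 `CCC1(c2ccccc2)CC(=O)C(C2CC(c3ccc(OCc4ccc(C(F)(F)F)cc4)cc3)Cc3ccccc32)=C(O)O1` differs from compound 2 by methyl in place of hydrogen on a saturated chain carbon bound to a saturated ring carbon, so that the methyl of compound 2 becomes ethyl. Among the measured compounds shown here, no measured step in this set touches that place, and the one single-place step that is known has no readable size. Nothing in the values shown gives reason to think that one added carbon here would carry a compound from the limit into the readable range of this assay.

Compound 4 is therefore expected to give about 15000 nM, within 5000 nM to 50000 nM, most probably again reported as a limit. The step that the limit leaves unreadable from compound 2 to compound 4 is expected to lie within the scatter.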

Compound 4, half-maximal inhibitory concentration: > 10000 nM
Compound 4 was reported as a limit (the forecaster's own chance of this, stated with the estimate: 75%); the middle value does not contradict the limit.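

In this assay compound 4 gives > 10000 nM, which is a limit of the assay and not a number. Compound 2 also stands at a limit, so no step can be read between compound 2 and compound 4: the limit of > 10000 nM in this assay, at which 3 of the 4 values shown sit. The compounds shown leave open whether the change from methyl to ethyl alters inhibition at all.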